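This account rests on a few compounds, and the source may have more. Where it says the series, first, only, none or still open, it means among the compounds named here.

Measured compounds:
Compound 1, `C=C(Br)C(=O)Nc1ccc(/C=C2\SC(=O)N(Cc3ccccc3)C2=O)cc1`: 3000 nM
Compound 2, `Nc1cccc(/C=C2\SC(=O)N(Cc3cccc(F)c3)C2=O)c1`: > 250000 nM

Going by the values given here, in a functional assay on FM3A cells (Mus musculus) for cytotoxicity, read by cell counting, with a stated time of 2 days (on this read-out lower numbers stand for stronger inhibition and higher numbers for weaker inhibition), compound 1 gives 3000 nM, the only number among the two values shown. Compound 2 gives > 250000 nM in this assay, which is a limit of the assay rather than a number. Compound 3, `C=C(Br)C(=O)Nc1ccc(/C=C2\SC(=O)N(Cc3cccc(Cl)c3)C2=O)cc1`, differs from compound 1 by chloro in place of hydrogen on an aromatic carbon. Among the compounds with values here, no step between measured compounds is available to gauge this change, so the account expects no shift beyond the usual scatter. Compound 3 is therefore estimated at 2500 nM, with a range from 800 nM to 8000 nM. The expected step is a 1.2-fold lower number from compound 1 to compound 3 (0.08 log units; within the scatter).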

Compound 3, half-maximal inhibitory concentration: 6100 nM
For compound 3 the middle estimate is 2.4-fold (0.39 log units) below the measured one; low and high end bracket the measured number.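

In this assay, chloro in place of hydrogen on an aromatic carbon, which turns benzyl into 3-chlorobenzyl, gives a 2.0-fold higher number from compound 1 to compound 3 (0.31 log units; beyond the scatter). Going by these compounds alone, this is the first reading at this position, and it shows that the position responds to this change, modestly and towards weaker inhibition. Nothing in the data shown accounts for this step. The compounds shown leave open whether fluoro, a methoxy group or an amine in place of the chloro would move the number the same way, or by how much.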